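This account rests on a few compounds, and the source may have more. Where it says the series, first, only, none or still open, it means among the compounds named here.

Working notes on the hydrazone series. Of the compounds shown here, three on the shared core have been measured in an assay on isolated protein for inhibition of Maltase-glucoamylase (Homo sapiens), with a stated time of 15 min; a lower number here means a stronger inhibitor, a higher number a weaker inhibitor. Compound 1 `O=C(N/N=C/c1ccccc1O)c1ccc(-c2nc3ccccc3s2)cc1` gives 5550 nM. Compound 2 `COc1ccc(/C=N/NC(=O)c2ccc(-c3nc4ccccc4s3)cc2)cc1OC` is reported in this assay as "not active" (no number reported), with no number attached. For the measured compounds named here, compound 3 `O=C(N/N=C/c1ccc([N+](=O)[O-])cc1)c1ccc(-c2nc3ccccc3s2)cc1` gives 26400 nM, which is the highest of the two numbers in hand; its nearest neighbour is compound 1, and the step of a 4.8-fold higher number from compound 1 to compound 3 (0.68 log units; beyond the scatter) is the only one-place change measured so far.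

Compound 4 `COc1cccc(/C=N/NC(=O)c2ccc(-c3nc4ccccc4s3)cc2)c1` is the next entry: 3-methoxyphenyl in place of 4-nitrophenyl on a carbon with a double bond to nitrogen. Going by the values given here, the one measured step that touches the same position, a 4.8-fold higher number from compound 1 to compound 3 (0.68 log units; beyond the scatter), was of modest size, so changes at this carbon have so far moved this assay only modestly. Compound 2, which carries two methoxy groups at this same position, gave no number at all, which argues against expecting a large gain for compound 4. On these grounds the expected outcome is a small step, a 1.3-fold higher number from compound 3 to compound 4 (0.12 log units; within the scatter), not clearly beyond the scatter in either direction. Compound 4 is therefore estimated at 35000 nM, with a range of 12000 nM to 110000 nM, and a real chance that only "not active" is reported.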

Compound 4, half-maximal inhibitory concentration: 11100 nM
Beside the measured number, compound 4's estimate is 3.2-fold (0.50 log units) above it, and the stated range ends above it.
By their numbers in this assay, from the lowest: compounds 1 and 4 (each within the scatter of the next); then compound 3.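

In this assay a single methoxy group on the phenyl ring at this carbon still gives a number, with a 2.4-fold lower number from compound 3 to compound 4 (0.38 log units; beyond the scatter), whereas compound 2, with its two methoxy groups, is reported only as "not active", so methoxy substitution at this carbon does not by itself rule out a measurable result. The second new step, a 2.0-fold higher number from compound 1 to compound 4 (0.30 log units; within the scatter), stays within the scatter, so this assay does not separate 3-methoxyphenyl from 2-hydroxyphenyl, and a hydroxyl group on this ring is not needed to reach this range, while compound 3 stays apart from both compound 1 and compound 4. No measurement at hand accounts for these differences.

The compounds shown leave open whether an amine or a carboxylic acid on this phenyl ring, or a cyclohexyl group or short alkyl chain in place of the ring, would give a number clearly apart from those of compound 1 and compound 4. For the compounds shown here, they also leave open what separates the single methoxy group of compound 4 from the pair on compound 2.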